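Lengthening the Chain by One Carbon Once More

The source may hold more compounds than are shown below. What is called first, only, known or untested is meant among the compounds shown, and "the series" means these compounds.

compound 1 `O=c1sc2ccccc2n1CCCCCCN1CCCCCC1`: 7.5 nM
compound 2 `CCC(=O)c1ccc2c(c1)sc(=O)n2CCCCN1CCCCCC1`: 10.3 nM
compound 3 `CCC(=O)c1ccc2c(c1)sc(=O)n2CCCCCN1CCCCCC1`: 12.2 nM

In an assay on cell membranes for displacement of a labelled ligand from Sigma non-opioid intracellular receptor 1 (Rattus norvegicus) (on this read-out higher numbers stand for weaker inhibition and lower numbers for stronger inhibition), compound 3 gives 12.2 nM; the three measured numbers all lie within the usual scatter of one another, so none of them can be called stronger or weaker. Compound 4 `CCC(=O)c1ccc2c(c1)sc(=O)n2CCCCCCN1CCCCCC1` differs from compound 3 by (azepan-1-yl)methyl in place of azepan-1-yl on a saturated chain carbon, five bonds along the chain from an aromatic nitrogen. Going by the values given here, the one measured step of the same kind, taken one bond closer to the aromatic nitrogen, is a 1.2-fold higher number from compound 2 to compound 3 (0.07 log units; within the scatter). The chain of compound 4 already has the length of that in compound 1, and compound 1 gives 7.5 nM. No shift beyond the scatter is therefore expected, with the step from compound 3 to compound 4 estimated at a 1.2-fold lower number from compound 3 to compound 4 (0.09 log units; within the scatter). For compound 4 the expected value is 10 nM, with a range from 4 nM to 25 nM.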

Compound 4, inhibition constant: 10.4 nM
Compound 4: the middle estimate sits 1.0-fold (0.02 log units) below what was measured; measured number inside the range.
By their numbers in this assay, from the lowest: compounds 1, 2, 4 and 3 (each within the scatter of the next).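

In this assay one further chain carbon brings a 1.2-fold lower number from compound 3 to compound 4 (0.07 log units; within the scatter) and two further carbons bring a 1.0-fold higher number from compound 2 to compound 4 (0.00 log units; within the scatter) for a combined change, so the numbers stay level across all three chain lengths carrying propanoyl. With the chain length held fixed, propanoyl in place of hydrogen on an aromatic carbon brings a 1.4-fold higher number from compound 1 to compound 4 (0.14 log units; within the scatter) as well, so this group also leaves the number within the scatter. Nothing measured here offers an explanation for this level stretch. Still open, from the compounds shown here alone, is whether a longer chain, or a piperidine ring in place of the azepane ring, would move the number beyond the scatter.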